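From 2-Methylphenyl to 4-Ethylphenyl: An Expected Flat Step

The compounds below may be only part of what the source reports. "The series", "measured", "known", "first", "only" and "open" are said of these compounds alone.

Compound 1, `O=C1CCC(N2C(=O)c3ccc(Nc4ccccn4)cc3C2=O)C(=O)N1`: 9%
Compound 2, `Cc1ccccc1Nc1cccc2c1C(=O)N(C1CCC(=O)NC1=O)C2=O`: 7%

Of the compounds shown here, two have so far been measured in an assay on FRT-Jurkat cells for inhibition of nuclear factor NF-kappa-B complex (Homo sapiens), read by flow cytometry, with a stated time of 24 h, tested at 10 uM; a lower number here means less inhibition, a higher number more inhibition at the concentration tested (going by the name of the read-out). Compound 1 `O=C1CCC(N2C(=O)c3ccc(Nc4ccccn4)cc3C2=O)C(=O)N1` gives 9%, and compound 2 `Cc1ccccc1Nc1cccc2c1C(=O)N(C1CCC(=O)NC1=O)C2=O` gives 7%. These two numbers lie within the usual scatter of each other, so compound 2 cannot be set apart from compound 1 on this reading; both sit at the low end of the scale, with little inhibition at the concentration tested.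

Compound 3 `CCc1ccc(Nc2cccc3c2C(=O)N(C2CCC(=O)NC2=O)C3=O)cc1` has not yet been measured. It differs from compound 2 in one place: 4-ethylphenyl in place of 2-methylphenyl on a nitrogen on an aromatic ring. For the measured compounds named here, no step between two measured compounds is available, so no measured change of this kind has been seen. Because compound 2 gives 7% and compound 1 gives 9%, there is no sign of any substituent at this nitrogen moving the number. The step of a number 2 percentage points higher from compound 2 to compound 3 (within the scatter) is expected to be one of no change beyond the scatter, in no set direction. Compound 3 is therefore expected to give 9%, with a range from 0% to 22%.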

Compound 3, a percentage reported as inhibition, at one concentration (the size of the read-out at that concentration, not a potency): 17%
The estimate for compound 3 lay 8 percentage points below the measured number; the measured number falls inside the stated range.
By their numbers in this assay, from the lowest: compounds 2, 1 and 3 (each within the scatter of the next).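

The first step read at this position, 4-ethylphenyl in place of 2-methylphenyl on a nitrogen on an aromatic ring, comes out in this assay as a number 10 percentage points higher from compound 2 to compound 3 (within the scatter), so this change cannot be told apart from no change on this reading. Two different alkyl-bearing phenyl groups on this nitrogen are therefore not separated by the read-out at the concentration tested, and this one step gives no ground for a trend with the size of the group. Nothing measured alongside these compounds bears on this result.

The step alters the length of the chain and its place on the phenyl ring together, so the compounds shown cannot say whether either alteration alone would matter; 4-methylphenyl or 2-ethylphenyl on the same nitrogen would pull the two apart. On these data alone, it also stays open whether a phenyl group carrying something other than a short alkyl chain, such as an amine or a carboxylic acid, would give a step beyond the scatter.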